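Anilide series at the bile acid receptor: piperazine replaces amino

The source may hold more compounds than are shown below. What is called first, only, known or untested is meant among the compounds shown, and "the series" means these compounds.

Among the measured compounds shown here, compound 1 `Cc1cc(NC(=O)c2ccc(Cl)cc2Cl)ccc1O` is the one member that returns a limit rather than a number. In an assay on isolated protein for antagonist activity at Bile acid receptor (Homo sapiens), read by HTRF, with a stated time of 30 min (a lower number here means a stronger inhibitor, a higher number a weaker inhibitor), compound 1 gives > 100000 nM, which is a limit of the assay. Compound 2 `CC(C)(C)c1cc(NC(=O)c2c(Cl)cc(N)cc2Cl)ccc1O` gives in this assay 5200 nM, the only numerical result so far. For the measured compounds named here, the one further value shown is a limit (the limit of > 100000 nM in this assay, at which 1 of the 2 values shown sits). Compound 3 `CC(C)(C)c1cc(NC(=O)c2c(Cl)cc(N3CCNCC3)cc2Cl)ccc1O` carries piperazin-1-yl in place of amino on an aromatic carbon, piperazin-1-yl in place of amino on an aromatic carbon, meta to two chloro groups and para to a large group. Going by the values given here, no comparable step has been measured, so the expected step of a 2.6-fold lower number from compound 2 to compound 3 (0.41 log units; beyond the scatter) is taken as a modest gain, barely beyond the scatter. Compound 3 is estimated at 2000 nM, with a range from 400 nM to 10000 nM.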

Compound 3, half-maximal inhibitory concentration: > 100000 nM
Compound 3 ended at the assay's limit; the forecaster's own chance of this, stated with the estimate: 10%; middle value at least 50-fold (1.69 log units) from the limit.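

Replacing amino by piperazin-1-yl on the aromatic carbon, meta to two chloro groups and para to a large group, gives an at least 19-fold higher number from compound 2 to compound 3 (1.28 log units; beyond the scatter) in this assay. This position therefore does not accept every nitrogen-linked group, and the six-membered non-aromatic ring is a large loss here. Compound 3 gives > 100000 nM, which is a limit of the assay, so the step has a floor but no measured size: the limit of > 100000 nM in this assay, at which 2 of the 3 values shown sit.

Open, as far as these compounds go, is whether the loss tracks the ring itself or its second nitrogen. Morpholin-4-yl, 4-methylpiperazin-1-yl or a small open-chain amine such as dimethylamino at this position could separate the two.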